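Chalcone series: replacing the aryl ketone substituent

The compounds below may be only part of what the source reports. "The series", "measured", "known", "first", "only" and "open" are said of these compounds alone.

Measured compounds in a functional assay on HepG2 cells (Homo sapiens) for antiproliferative activity, read by MTT assay, with a stated time of 48 h; a lower number here means a stronger inhibitor, a higher number a weaker inhibitor:
- compound 1, `CCCCCCOc1ccc(C(=O)/C=C/c2c(/C=C/c3ccc(OC)cc3)cc(OC)cc2OC)cc1`: 16.2 ug/mL
- compound 2, `COc1ccc(/C=C/c2cc(OC)cc(OC)c2/C=C/C(=O)c2ccc(N)cc2)cc1`: 7.5 ug/mL
- compound 3, `COc1ccc(/C=C/c2cc(OC)cc(OC)c2/C=C/C(=O)c2ccc(C)c(C)c2)cc1`: 0.2 ug/mL

Compound 3 gives the lowest number of the three in this assay; its nearest neighbour is compound 2, and the gap to compound 1 is wider still. Both measured steps change only the ring on the carbonyl side of the shared core. The first, a 2.2-fold lower number from compound 1 to compound 2 (0.33 log units; beyond the scatter), is modest. The second, a 38-fold lower number from compound 2 to compound 3 (1.57 log units; beyond the scatter), is large and shows that this position moves the number strongly.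

Compound 4, `COc1ccc(/C=C/c2cc(OC)cc(OC)c2/C=C/C(=O)c2ccc(F)cc2)cc1`, has not yet been measured in this assay. Its difference from compound 3 is 4-fluorophenyl in place of 3,4-dimethylphenyl on a carbonyl carbon. Going by the values given here, the step from compound 2 to compound 3 bears most directly on it, since it alters the same ring; no measured pair tests a fluorine there, and no unsubstituted phenyl is available for comparison. Given the spread between compound 2 and compound 3, a change at this ring is expected to move the number, and the estimate places compound 4 between those two, nearer compound 3: the expected step is a 7.5-fold higher number from compound 3 to compound 4 (0.88 log units; beyond the scatter). For compound 4 the estimated value in this assay is 1.5 ug/mL, with a range from 0.3 ug/mL to 8 ug/mL.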

Compound 4, half-maximal inhibitory concentration: 12.2 ug/mL
Beside the measured number, compound 4's estimate is 8.1-fold (0.91 log units) below it, and the stated range ends below it.
By their numbers in this assay, from the lowest: compound 3; then compounds 2, 4 and 1 (each within the scatter of the next, the first and the last beyond it).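

In this assay, 4-fluorophenyl in place of 3,4-dimethylphenyl gives a 61-fold higher number from compound 3 to compound 4 (1.79 log units; beyond the scatter), although the two groups match in having one carbon-only aromatic ring, no hydrogen-bond donors or acceptors and no net charge, so the low number of compound 3 is not shared by every ring of that description at this carbonyl carbon. Fluoro in place of amino gives a 1.6-fold higher number from compound 2 to compound 4 (0.21 log units; within the scatter) and fluoro in place of hexyloxy gives a 1.3-fold lower number from compound 1 to compound 4 (0.12 log units; within the scatter), so compound 4 is not separated from either of these and, among the four compounds, only compound 3 stands apart. Nothing available here explains why the 3,4-dimethylphenyl group stands apart in this way.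

The compounds shown leave open whether the low number requires both methyl groups of the 3,4-dimethylphenyl ring or just one, and how an unsubstituted phenyl ring compares. They also leave open whether a chloro or trifluoromethyl group on this ring would give a number close to that of compound 4 or close to that of compound 3.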